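Replacing a Methyl with Oxetan-3-yl in Compound 1

A few compounds are considered here, and "the series" means these few. Any claim that something is new, unique, unknown or untested is made for them only; others in the source may bear on it.

In an ADME assay on microsomes from liver (Homo sapiens) for pharmacokinetics (on this read-out higher numbers stand for fast clearance and lower numbers for slow clearance), compound 1 (`Cc1c(Nc2nc(N)c3c(C#N)c(N4CCC[C@H]4C)n(C)c3n2)cnn1C`) gives 41.7 mL/min/kg. This number lies within the usual scatter of both other measured compounds: compound 2 (`Cc1c(Nc2nc(N)c3c(C#N)c(N4CCC[C@H]4C)n(C)c3n2)cnn1[C@H]1CCOC1`) at 23.3 mL/min/kg and compound 3 (`Cc1nn(CC(C)(C)O)cc1Nc1nc(N)c2c(C#N)c(N3CCC[C@H]3C)n(C)c2n1`) at 50 mL/min/kg.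

The unmeasured compound 4 (`Cc1c(Nc2nc(N)c3c(C#N)c(N4CCC[C@H]4C)n(C)c3n2)cnn1C1COC1`) keeps the core of compound 1 and changes one group on an aromatic nitrogen: oxetan-3-yl in place of methyl on an aromatic nitrogen. In other words, 1,5-dimethyl-1H-pyrazol-4-yl becomes 5-methyl-1-(oxetan-3-yl)-1H-pyrazol-4-yl.

The closest measured precedent is the change to compound 2, where oxolan-3-yl takes the place of the same methyl: a 1.8-fold lower number from compound 1 to compound 2 (0.25 log units; within the scatter). That single step stays within the scatter, so it offers only weak guidance. It suggests a modest move in the same direction, though no change at all would fit equally well.

The expected step is a 1.4-fold lower number from compound 1 to compound 4 (0.14 log units; within the scatter), which is an estimate and no larger than the scatter. For compound 4, the estimated clearance is 30 mL/min/kg, with an expected range from 17 mL/min/kg to 50 mL/min/kg.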

Compound 4, clearance: 14.3 mL/min/kg
Compound 4: the middle estimate sits 2.1-fold (0.32 log units) above what was measured; the whole stated range lies above it.
By their numbers in this assay, from the lowest: compounds 4, 2, 1 and 3 (each within the scatter of the next, the first and the last beyond it).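

In this assay, this aromatic nitrogen now gives a step that clears the scatter: oxetan-3-yl in place of methyl gives a 2.9-fold lower number from compound 1 to compound 4 (0.46 log units; beyond the scatter), whereas the earlier oxolan-3-yl change stayed within it. The two oxygen-bearing rings cannot be told apart, since the swap between them gives a 1.6-fold lower number from compound 2 to compound 4 (0.21 log units; within the scatter), which is within the scatter. Nothing available here explains the drop in clearance seen with oxetan-3-yl.

The compounds shown leave open whether the ring oxygen matters, which cyclobutyl, a four-membered ring of carbon alone, could help to test on the same nitrogen. They also leave open how a four-membered ring with a nitrogen in place of the oxygen, such as azetidin-3-yl, would behave on the same core.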